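From a methyl to a hydroxy on compound 2

A few compounds are considered here, and "the series" means these few. Any claim that something is new, unique, unknown or untested is made for them only; others in the source may bear on it.

In a functional assay on KB cells (Homo sapiens) for inhibition, read by sulforhodamine B assay (on this read-out lower numbers stand for stronger inhibition of growth and higher numbers for weaker inhibition of growth), compound 2 (`COc1cc(-c2ccc(-c3ccc(-c4nc5cc(C)ccc5[nH]4)cc3)cc2)cc(OC)c1OC`) gives 2110 nM. Within the data shown here, compound 1 (`COc1ccc(-c2ccc(-c3ccc(-c4nc5cc(C)ccc5[nH]4)cc3)cc2)cc1OC`) gives 2190 nM, so these two sit together at the low end of the three numbers known so far. Compound 3 (`Fc1ccc(-c2ccc(-c3ccc(-c4nc5ccccc5[nH]4)cc3)cc2)cc1`) stands well apart at 41300 nM.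

Compound 4 (`COc1cc(-c2ccc(-c3ccc(-c4nc5c(O)cccc5[nH]4)cc3)cc2)cc(OC)c1OC`) differs from compound 2 in one place: 4-hydroxy-1H-benzimidazol-2-yl in place of 5-methyl-1H-benzimidazol-2-yl on an aromatic carbon.

Among the measured compounds shown here, only one measured step bears even indirectly on this change. It is a 1.0-fold lower number from compound 1 to compound 2 (0.02 log units; within the scatter), which lies within the scatter, but it concerns a methoxy in place of hydrogen, not the group that changes here. Compound 2 and compound 3 differ in more than one place, so the value of compound 3, 41300 nM, cannot be tied to any single change. It does show that a much higher number can occur among these compounds, so the range below is left wider on its upper side.

No measurement gives the size of this swap directly, so no shift beyond the scatter in this assay is expected. The estimated step is a 1.4-fold higher number from compound 2 to compound 4 (0.15 log units; within the scatter). For compound 4 the expected value is 3000 nM, with an estimated range of 700 nM to 15000 nM.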

Compound 4, concentration for 50% growth inhibition: 2110 nM
Compound 4: middle estimate off by 1.4-fold (0.15 log units), on the high side, within the range that was stated.
By their numbers in this assay, from the lowest: compounds 2, 4 and 1 (each within the scatter of the next); then compound 3.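

In this assay, putting 4-hydroxy-1H-benzimidazol-2-yl in place of 5-methyl-1H-benzimidazol-2-yl gives no change at the digits printed from compound 2 to compound 4 (within the scatter), and this is the only step shown that touches this part of the molecule. The two compounds cannot be told apart here, even though the entering group has 2 hydrogen-bond donors and 2 hydrogen-bond acceptors against 1 of each in the group that leaves, so this read-out tolerates this particular exchange on the shared core. No measurement is available that would explain this result.

Because the methyl group goes and the hydroxy group arrives in a single step, with the two groups named at different ring positions, the compounds shown cannot separate the effect of removing one from the effect of adding the other. It also remains open whether a larger or charged group on this ring, such as an amine, a carboxylic acid or a longer alkyl chain, would keep the number within the scatter of these compounds or move it clearly away.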